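The source may hold more compounds than are shown below. What is called first, only, known or untested is meant among the compounds shown, and "the series" means these compounds.

Measured in a physicochemical assay for solubility, at pH 7.4; a lower number here means a less soluble compound, a higher number a more soluble compound:
- compound 1 `Cc1cc(NC(=O)Nc2cccc(C(F)(F)F)c2)c2ccccc2n1`: 100 nM
- compound 2 `COc1cccc(NC(=O)Nc2cc(C)nc3ccccc23)c1`: 1200 nM

Compound 2 holds the higher of these two numbers. Compound 3 `Cc1cc(NC(=O)Nc2cccc(C(C)(C)C)c2)c2ccccc2n1` has not yet been measured. It has tert-butyl in place of methoxy on an aromatic carbon.

Within the data shown here, one measured step bears on this change: a 12-fold higher number from compound 1 to compound 2 (1.08 log units; beyond the scatter), a large step, with methoxy entering in place of trifluoromethyl. Tert-butyl is not trifluoromethyl, so this comparison is only a partial guide. Removing methoxy here is expected to give a step of similar size in the opposite direction, estimated as a 10-fold lower number from compound 2 to compound 3 (1.00 log units; beyond the scatter). For compound 3 the expected value in this assay is 120 nM, with an estimated range of 30 nM to 450 nM.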

Compound 3, solubility: 34700 nM
For compound 3 the middle estimate is 290-fold (2.46 log units) below the measured one, and the stated range ends below it.
By their numbers in this assay, from the lowest: compound 1; then compound 2; then compound 3.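

Tert-butyl gives a 29-fold higher number from compound 2 to compound 3 (1.46 log units; beyond the scatter) and a 350-fold higher number from compound 1 to compound 3 (2.54 log units; beyond the scatter) in this assay so methoxy is not the only group at this position that raises the number above that of compound 1. Compound 3 holds the highest number of the three even though tert-butyl, made of carbon only, has 0 hydrogen-bond acceptors where methoxy has 1, so a high number here does not need an acceptor at this position. Nothing available explains this rise. From the compounds shown here alone, it remains open whether the high number is special to tert-butyl or would also appear with a longer carbon chain, and how an amine at this position would compare.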